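The source may report more compounds than this note shows. Statements on the series, on what has been measured and on what is new or still open speak of the compounds shown alone.

In a functional assay on Huh-5-2 cells (Homo sapiens), read by MTT assay (a lower number here means that less compound is tolerated, a higher number that more compound is tolerated), compound 1 `O=C(O)c1ccc2c(c1)nc(-c1ccc(OCc3ccccc3-c3ccc(Cl)cc3)cc1)n2C1CCCCC1` gives 25000 nM, compound 2 `Cc1nc(COc2ccc(-c3nc4cc(C(=O)O)ccc4n3C3CCCCC3)cc2)c(-c2ccc(Cl)cc2)o1` gives 39000 nM and compound 3 `O=C(O)c1ccc2c(c1)nc(-c1ccc(OCc3cc(C(=O)NCCO)ccc3-c3ccc(Cl)cc3)cc1F)n2C1CCCCC1` gives 26000 nM. Compound 3 lies within the usual scatter of both others, so these three cannot be ranked. Compound 4 `CC(=O)N(C)c1ccc(-c2ccc(Cl)cc2)c(COc2ccc(-c3nc4cc(C(=O)O)ccc4n3C3CCCCC3)c(F)c2)c1` has acetyl(methyl)amino in place of the (2-hydroxyethyl)carbamoyl of compound 3, on an aromatic carbon para to a 4-chlorophenyl group (acetyl(methyl)amino in place of (2-hydroxyethyl)carbamoyl on an aromatic carbon). Among the compounds with values here, no measured pair shows this swap directly. Compound 1 at 25000 nM and compound 3 at 26000 nM differ in more than one place yet stay within the scatter, so no step beyond the scatter is expected in this assay. The expected change is a 1.1-fold higher number from compound 3 to compound 4 (0.03 log units; within the scatter). For compound 4 the estimated value is 28000 nM, with a range from 13000 nM to 55000 nM.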

Compound 4, half-maximal cytotoxic concentration: 26000 nM
Compound 4: the middle estimate sits 1.1-fold (0.03 log units) above what was measured; the range from low to high includes it.
By their numbers in this assay, from the lowest: compounds 1, 3, 4 and 2 (each within the scatter of the next).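

In this assay, putting acetyl(methyl)amino in place of (2-hydroxyethyl)carbamoyl on this aromatic carbon, para to a 4-chlorophenyl group, gives no change at the digits printed from compound 3 to compound 4 (within the scatter). Within the data shown here, this is the first comparison here between compounds that differ in one place, and it shows that going from 2 hydrogen-bond donors to 0 in this group leaves the tolerated concentration within the scatter. Nothing measured here offers a reason for this. As far as these compounds go, whether an amine or a carboxylic acid on the same carbon would also stay within the scatter remains open.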